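From 4-methylphenyl to pyridin-2-yl on the shared core

The compounds below may be only part of what the source reports. "The series", "measured", "known", "first", "only" and "open" are said of these compounds alone.

In a physicochemical assay for solubility, in phosphate buffer, at pH 7.4 (on this read-out lower numbers stand for lower solubility and higher numbers for higher solubility), compound 1 `CN(C)C1CCN(c2nccnc2OC2CN(c3ccc4ccccc4n3)C2)CC1` gives 500000 nM. Compound 2 `Cc1ccc(-c2nccnc2OC2CN(c3ccc4ccccc4n3)C2)cc1` reads < 1000 nM, which is a limit of the assay and not a number. Compound 3 `c1ccc(-c2nccnc2OC2CN(c3ccc4ccccc4n3)C2)nc1` carries pyridin-2-yl in place of 4-methylphenyl on an aromatic carbon, next to the ring nitrogen: pyridin-2-yl in place of 4-methylphenyl on an aromatic carbon.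

Within the data shown here, one measured step bears on this change: the large step of an at least 500-fold lower number from compound 1 to compound 2 (2.69 log units; beyond the scatter), which put 4-methylphenyl in place of 4-(dimethylamino)piperidin-1-yl. Compound 3 keeps a six-membered aromatic ring where compound 2 has one, so a step of that size is not expected here. A small rise in this assay is expected, and the reading may stay at the limit. The estimated change is an at least 2.0-fold higher number from compound 2 to compound 3 (0.30 log units; that floor lies within the scatter). Compound 3 is expected at 2000 nM, with an estimated range of 700 nM to 10000 nM.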

Compound 3, solubility: 349000 nM
Compound 3: middle estimate off by 170-fold (2.24 log units), on the low side; measured number above the stated range.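

At this aromatic carbon, next to the ring nitrogen, exchanging one six-membered aromatic ring for another is not a minor change in this assay: pyridin-2-yl in place of 4-methylphenyl gives an at least 340-fold higher number from compound 2 to compound 3 (2.54 log units; beyond the scatter). Compound 2 stands at a limit of the assay and not at a number, so the true size of this step is not fixed: the limit of < 1000 nM in this assay, at which 1 of the 3 values shown sits. With pyridin-2-yl at this carbon, the 4-(dimethylamino)piperidin-1-yl group is not needed to reach the level of compound 1, as the two do not separate beyond the scatter, with a 1.4-fold lower number from compound 1 to compound 3 (0.16 log units; within the scatter).

The compounds shown do not separate the ring nitrogen of pyridin-2-yl from the loss of the methyl; plain phenyl at this carbon would do so, and pyridin-3-yl or pyridin-4-yl would test where that nitrogen must sit. Also open, going by these compounds, is how a morpholine or a carboxylic acid at this carbon would read in this assay.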